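The source may hold more compounds than are shown below. What is called first, only, known or untested is meant among the compounds shown, and "the series" means these compounds.

The measured compounds and their values in a functional assay on the whole organism with Mus musculus as the target; on this read-out lower numbers stand for smaller maximal responses and higher numbers for larger maximal responses:

Compound 1, `CCOC(=O)Cn1c(=O)n(C2OC(CO)[C@@H](O)[C@H]2O)c2nc(N)nc(O)c21`: 58%
Compound 2, `C=CCn1c(=O)n([C@@H](CO)OC(CO)CO)c2nc(N)nc(O)c21`: 6%
Compound 3, `C=CCn1c(=[Se])n(C2OC(CO)[C@@H](O)[C@H]2O)c2nc(N)nc(O)c21`: 107%

Among these three numbers compound 1 stands second highest. Its nearest neighbour is compound 3, whose value lies higher by an amount beyond the usual scatter; the furthest is compound 2, whose value lies lower, again beyond the scatter. Among the compounds with values here, compound 2 and compound 3 differ from compound 1 in more than one place, so no single step between measured compounds can be read off, and nothing is known about what a change at only one position does to this read-out.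

The step under consideration leads from compound 1 to compound 4, `Nc1nc(O)c2c(n1)n(C1OC(CO)[C@@H](O)[C@H]1O)c(=O)n2Cc1ccc([N+](=O)[O-])cc1`, which has not yet been measured in this assay. The change is 4-nitrophenyl in place of ethoxycarbonyl on a saturated chain carbon bound to an aromatic nitrogen. Cut one bond further out it reads (ethoxycarbonyl)methyl to 4-nitrobenzyl, while the rest of the shared core and the sugar remain as in compound 1.

Within the data shown here, with no step of one change among the measured compounds to lean on, no direction can be argued from the data; a step within the usual scatter is expected, and the estimated step of a number 3 percentage points lower from compound 1 to compound 4 (within the scatter) expresses this. Compound 4 is accordingly expected to give about 55% in this assay, with a plausible range from 20% to 95%.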

Compound 4, largest response reached (reported as maximal response), in percent of the reference or control that the assay uses: 16%
For compound 4 the middle estimate is 39 percentage points above the measured one, outside the stated range (below it).
By their numbers in this assay, from the lowest: compounds 2 and 4 (each within the scatter of the next); then compound 1; then compound 3.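

Within the data shown here, this is the first single change that can be read in this set. In this assay, putting 4-nitrophenyl in place of ethoxycarbonyl on a saturated chain carbon bound to an aromatic nitrogen gives a number 42 percentage points lower from compound 1 to compound 4 (beyond the scatter) and so marks a large step. The earlier compounds shown here differed from compound 1 in more than one place and could not isolate this position, whereas here the sugar and the rest of the shared core stay the same, which shows that the maximal response depends strongly on the group carried at this place. Nothing available on the properties of these two groups accounts for the size of this step.

The compounds shown cannot separate the part played by the entering aromatic ring and its nitro group from the part played by the loss of the ethyl ester, so it remains open whether a plain benzyl or a 4-aminobenzyl would behave like the 4-nitrobenzyl of compound 4. As far as these compounds go, it also remains open whether a carboxylic acid in place of the ethyl ester would keep the response of compound 1 or lower it.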